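The compounds below may be only part of what the source reports. "The series", "measured", "known", "first", "only" and "open" are said of these compounds alone.

Of the compounds shown here, three built on a shared core have been tested in a functional assay on HOS-TE85 cells (Homo sapiens) for inhibition, read by CCK-8 assay, with a stated time of 72 h; a higher number here means a weaker inhibitor, a lower number a stronger inhibitor. There, compound 1 `Cc1ccnc(N2C(=O)CS[C@@H]2c2cccc(C(=O)NCCCCn3cccn3)c2)c1` gives 21.9 nM, a true measured number. Compound 2 `O=C(NCCCCc1ccccc1)c1cccc(C2SCC(=O)N2c2cnccn2)c1` gives > 1000 nM, which is a limit of the assay and not a number. Compound 3 `COc1ccccc1N1C(=O)CSC1c1cccc(C(=O)NCCCCn2cncn2)c1` gives > 1000 nM, which is also a limit and not a number. Compound 3 therefore has no exact place on the scale, and the picture so far includes (the limit of > 1000 nM in this assay, at which 2 of the 3 values shown sit).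

Compound 4 `COc1ccccc1N1C(=O)CSC1c1cccc(C(=O)NCCCCn2cccn2)c1` differs from compound 3 in one place: 1H-pyrazol-1-yl in place of 1H-1,2,4-triazol-1-yl on a saturated chain carbon, four bonds along the chain from an amide-type nitrogen. Here 1H-pyrazol-1-yl stands in place of 1H-1,2,4-triazol-1-yl on a saturated chain carbon, four bonds along the chain from an amide-type nitrogen.

Within the data shown here, no two measured compounds differ in just one place, so no direct step shows how large this change should be. Among the measured compounds shown here, the only guide is that the 1H-pyrazol-1-yl group also occurs in compound 1, at 21.9 nM. A lower number than the limit of compound 3, beyond the scatter, is therefore expected in this assay, but compound 1 also differs from compound 3 elsewhere, so the size stays uncertain. The estimated change is an at least 4.0-fold lower number from compound 3 to compound 4 (0.60 log units; beyond the scatter). For compound 4 the expected value is 250 nM, with an estimated range from 40 nM to 1500 nM.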

Compound 4, half-maximal inhibitory concentration: 91.7 nM
Estimate against measurement, compound 4: 2.7-fold (0.44 log units) above; the range from low to high includes it.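

In this assay, putting 1H-pyrazol-1-yl in place of 1H-1,2,4-triazol-1-yl gives an at least 10-fold lower number from compound 3 to compound 4 (1.03 log units; beyond the scatter), the first direct step among these compounds. It shows that this position, on a saturated chain carbon, four bonds along the chain from an amide-type nitrogen, is sensitive: with the rest of the molecule unchanged, replacing a five-membered aromatic ring with 3 hetero atoms by one with 2 moves the result from a limit to a true measured number. The full size of the step stays unknown because compound 3 sits at a limit and not at a number: the limit of > 1000 nM in this assay, at which 2 of the 4 values shown sit.

The compounds shown leave open whether other end groups at this place, such as 1H-imidazol-1-yl or a dimethylamino group, or a longer chain, would keep this gain. They also do not tell why the ring change matters, or whether it would give a step of similar size with different groups elsewhere on the shared core.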